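A few compounds are considered here, and "the series" means these few. Any claim that something is new, unique, unknown or untested is made for them only; others in the source may bear on it.

Measured compounds and their values:
- compound 1, `O=c1cc(O)c2ccc(OCc3cccc(F)c3)cc2o1`, gives 0%
- compound 2, `O=c1cc(O)c2ccc(OCc3cccc(Br)c3)cc2o1`, gives 0%
- compound 3, `COc1cc(=O)oc2cc(OCc3cccc(F)c3)ccc12`, gives 49%

All three were tested in an assay on isolated protein (strain Sprague-Dawley) for inhibition of Amine oxidase [flavin-containing] A (Rattus norvegicus), read by spectrophotometry, with a stated time of 5 min, tested at 10 uM; a higher number here means more inhibition at the concentration tested (going by the name of the read-out), a lower number less inhibition. Compound 1 and compound 2 both show no measurable inhibition there; their step is no change at the digits printed from compound 1 to compound 2 (within the scatter), and the change behind it is bromo in place of fluoro on an aromatic carbon. Compound 3 stands apart: the step of a number 49 percentage points higher from compound 1 to compound 3 (beyond the scatter) is large and rests on the change (methyl in place of hydrogen on an oxygen on an aromatic ring), which is also how the core of compound 3 differs from the core of compound 1.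

Compound 4, `COc1cc(=O)oc2cc(OCc3cccc(Br)c3)ccc12`, has not yet been tested in this assay. It differs from compound 3 by bromo in place of fluoro on an aromatic carbon. This is the same change, at the same place, that turned compound 1 into compound 2, where the read-out did not move. Both of those compounds, however, sit at zero, so that pair cannot show whether the change would shift a compound that already inhibits, as compound 3 does.

On the strength of compound 3 giving 49% and of the unchanged step no change at the digits printed from compound 1 to compound 2 (within the scatter), the change is expected to alter the read-out little, so that compound 4 is estimated to give about 50%, between 30% and 70%, a step of a number 1 percentage points higher from compound 3 to compound 4 (within the scatter) from its neighbour.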

Compound 4, a percentage reported as inhibition, at one concentration (the size of the read-out at that concentration, not a potency): 27%
Compound 4: middle estimate off by 23 percentage points, on the high side; measured number below the stated range.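

In this assay, bromo in place of fluoro is not a neutral change on the core of compound 3, where the step is a number 22 percentage points lower from compound 3 to compound 4 (beyond the scatter), so the flat result on the core of compound 1 did not carry over: the same change on two cores in this assay, no change at the digits printed (within the scatter) from compound 1 to compound 2 and a number 22 percentage points lower (beyond the scatter) from compound 3 to compound 4, 22 percentage points apart, beyond the scatter of two such steps. Seen from the other direction, methyl in place of hydrogen on the oxygen raises the number with either halogen, a number 49 percentage points higher from compound 1 to compound 3 (beyond the scatter) with fluoro and a number 27 percentage points higher from compound 2 to compound 4 (beyond the scatter) with bromo, but the size of that gain does not carry over intact: the same change on two cores in this assay, a number 49 percentage points higher (beyond the scatter) from compound 1 to compound 3 and a number 27 percentage points higher (beyond the scatter) from compound 2 to compound 4, 22 percentage points apart, beyond the scatter of two such steps. Compound 1 gives 0% and compound 2 gives 0%, and a read-out at zero has no room to fall, so these two compounds cannot show that the halogen change truly does nothing on their core, and a single pair on each core, read at one concentration, gives no measure of potency.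

Going by these compounds, it remains open whether chloro or a methyl group on the aromatic ring would keep more of the inhibition seen with fluoro. On these data alone, it is equally open whether a longer chain such as ethyl on the oxygen, or an amine in place of the methoxy group, would raise or lower the number.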